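Expected Activity of a 4-Fluorophenyl Analogue, Compound 4

The compounds below may be only part of what the source reports. "The series", "measured", "known", "first", "only" and "open" are said of these compounds alone.

Compound 1 `COc1cc(-c2nnc(SCc3cccc(Br)c3)o2)ccc1O`: 48100 nM in a functional assay on cells (T-cell, Mus musculus, strain BALB/c) for inhibition, read by MTT assay, with stated times of 24 h and 72 h; on this read-out higher numbers stand for weaker inhibition and lower numbers for stronger inhibition
Compound 2 `COc1cc(-c2nnc(SCc3ccccc3F)o2)ccc1O`: 5790 nM
Compound 3 `COc1cc(-c2nnc(SCc3cccc(Cl)c3)o2)ccc1O`: 8290 nM

Compound 3 stands second highest of the three numbers in this assay. Its nearest neighbour is within the scatter, a 1.4-fold higher number from compound 2 to compound 3 (0.16 log units; within the scatter), and its furthest is beyond it, a 5.8-fold lower number from compound 1 to compound 3 (0.76 log units; beyond the scatter). Compound 4 `COc1cc(-c2nnc(SCc3ccc(F)cc3)o2)ccc1O` is not yet measured; it differs from compound 3 as follows: 4-fluorophenyl in place of 3-chlorophenyl on a saturated chain carbon bound to a sulfur. Among the compounds with values here, two measured steps bear on this change: an 8.3-fold lower number from compound 1 to compound 2 (0.92 log units; beyond the scatter) and a 1.4-fold higher number from compound 2 to compound 3 (0.16 log units; within the scatter). Exchanging one fluorophenyl or chlorophenyl for another moved the number little, so the step from compound 3 to compound 4 is expected to stay within the scatter, a 1.2-fold lower number from compound 3 to compound 4 (0.07 log units; within the scatter). Compound 4 is therefore estimated at 7000 nM, within 2500 nM to 20000 nM.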

Compound 4, half-maximal inhibitory concentration: 8190 nM
Beside the measured number, compound 4's estimate is 1.2-fold (0.07 log units) below it; measured number inside the range.
By their numbers in this assay, from the lowest: compounds 2, 4 and 3 (each within the scatter of the next); then compound 1.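

In this assay, 4-fluorophenyl in place of 2-fluorophenyl on this saturated chain carbon bound to a sulfur gives a 1.4-fold higher number from compound 2 to compound 4 (0.15 log units; within the scatter), and in place of 3-chlorophenyl it gives a 1.0-fold lower number from compound 3 to compound 4 (0.01 log units; within the scatter), so a third halogenated phenyl now sits in the same range. The 3-bromophenyl group alone stands apart, with a 5.9-fold lower number from compound 1 to compound 4 (0.77 log units; beyond the scatter). Nothing available explains this separation. On these data alone, whether the gap follows from bromo itself remains open, as a 4-bromophenyl or 2-bromophenyl group would be needed to tell. As far as these compounds go, how an unsubstituted phenyl or an aminophenyl would read at this place also remains open.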